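Changing the Phenyl Group on the Ring Amine

This account rests on a few compounds, and the source may have more. Where it says the series, first, only, none or still open, it means among the compounds named here.

Measured so far in an assay on HEK293 cells for inhibition of Voltage-dependent T-type calcium channel subunit alpha-1G (Homo sapiens), read by fluorescence, tested at 10 uM; a higher number here means more inhibition at the concentration tested (going by the name of the read-out), a lower number less inhibition:
Compound 1 `CCCc1nc(-c2ccccc2)c(CNCCN2CCN(c3ccccc3F)CC2)o1` gives 46.5%
Compound 2 `CCCc1nc(-c2ccccc2)c(CNCCN2CCN(c3cccc(C)c3)CC2)o1` gives 43.1%

Compound 2 sits beside compound 1: the gap a number 3.4 percentage points lower from compound 1 to compound 2 (within the scatter) is within the scatter, so the two are not told apart. Compound 3 `CCCc1nc(-c2ccccc2)c(CNCCN2CCN(c3ccccc3Cl)CC2)o1` is the next step from compound 2 (2-chlorophenyl in place of 3-methylphenyl on an amine nitrogen in a ring). Within the data shown here, the one measured step, a number 3.4 percentage points lower from compound 1 to compound 2 (within the scatter), also swapped one phenyl group for another on this ring nitrogen and stayed within the scatter, so for compound 3 a step of about a number 2.9 percentage points higher from compound 2 to compound 3 (within the scatter) is expected, none beyond the scatter. Compound 3 is therefore estimated at 46%, between 31% and 61%.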

Compound 3, a percentage reported as inhibition, at one concentration (the size of the read-out at that concentration, not a potency): 60.1%
For compound 3 the middle estimate is 14.1 percentage points below the measured one, and the stated range covers the measured number.
By their numbers in this assay, from the lowest: compounds 2 and 1 (each within the scatter of the next); then compound 3.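

In this assay, the phenyl group on this ring amine can matter after all: 2-chlorophenyl in place of 3-methylphenyl gives a number 17 percentage points higher from compound 2 to compound 3 (beyond the scatter). The group's atoms alone can also make a difference, since chloro in place of fluoro on an aromatic carbon gives a number 13.6 percentage points higher from compound 1 to compound 3 (beyond the scatter). Both steps are modest, but they show that not every phenyl swap here stays as close as the first pair did.

On these data alone, whether bromo or methoxy in place of the chloro would raise the number further remains open. Nothing measured here accounts for either step.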